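Dropping the Phenoxy Group: What Cytotoxicity to Expect

The compounds below may be only part of what the source reports. "The series", "measured", "known", "first", "only" and "open" are said of these compounds alone.

Compound 1, `COC(=O)[C@H](CSC)NC(=O)c1cnc2ccccc2c1Cl`: 68.4 uM
Compound 2, `O=C(NCCO)c1c[nH]c2ccc(Oc3ccccc3)cc2c1=O`: > 100 uM

Going by the values given here, both compounds have been tested in an ADME assay on CCRF-CEM cells (Homo sapiens) for cytotoxicity; on this read-out higher numbers stand for lower toxicity in this test and lower numbers for higher toxicity in this test. For compound 2 the reading > 100 uM is a limit of the assay rather than a number, so compound 2 stands at the limit of > 100 uM in this assay, at which 1 of the 2 values shown sits. Among the compounds with values here, compound 1 and compound 2 share no common core, so no step between two measured compounds can be drawn from these two values.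

Compound 3, `O=C(NCCO)c1c[nH]c2ccccc2c1=O`, differs from compound 2 in one place: hydrogen in place of phenoxy on an aromatic carbon. Within the data shown here, since no measured step is available, the size of the change in this assay is unknown; the expectation is for no shift beyond the usual scatter, with the reading most likely staying at the limit. Compound 3 is therefore estimated at about 150 uM, within a range of 60 uM to 400 uM. The estimated step is a step that the limit leaves unreadable from compound 2 to compound 3.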

Compound 3, half-maximal toxic concentration: > 100 uM
Compound 3 was reported as a limit (the forecaster's own chance of this, stated with the estimate: 70%); the middle value is on the limit's open side.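

In this assay, going by these compounds alone, compound 2 and compound 3 are both reported only as a limit, so no step from one to the other can be read: the limit of > 100 uM in this assay, at which 2 of the 3 values shown sit. Still open, going by these compounds, is whether hydrogen in place of phenoxy changes the toxic concentration at all, since the true values of both compounds lie beyond the limit.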